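Swapping Benzyl for 4-Chlorophenyl on a Ring Nitrogen

The source may report more compounds than this note shows. Statements on the series, on what has been measured and on what is new or still open speak of the compounds shown alone.

Three compounds have been measured in a functional assay on A549 cells (Homo sapiens) for antiproliferative activity, read by MTT assay, with a stated time of 72 h; on this read-out lower numbers stand for stronger inhibition and higher numbers for weaker inhibition:

Compound 1 `CCCCCCC#Cc1c(CCCCCC)oc2nc(=O)n(Cc3cn(-c4ccc(Cl)cc4)nn3)cc12` gives > 100000 nM, which is a limit of the assay rather than a number.
Compound 2 `CCCCCCC#Cc1c(CCCCCC)oc2nc(=O)n(Cc3cn(Cc4ccccc4)nn3)cc12` gives 21900 nM.
Compound 3 `O=c1nc2oc(CCCCl)cc2cn1Cc1cn(Cc2ccccc2)nn1` gives 27900 nM.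

Compounds 2 and 3 carry the same group on the ring nitrogen but differ in their cores; the difference between the two cores is not broken down here, and their two numbers lie within the usual scatter of each other. Between compound 2 and compound 1 the change is 4-chlorophenyl in place of benzyl on an aromatic nitrogen. It gave an at least 4.5-fold higher number from compound 2 to compound 1 (0.65 log units; beyond the scatter), a size known only as a lower bound because compound 1 sits at the limit of > 100000 nM in this assay, at which 1 of the 3 values shown sits.

Compound 4 `O=c1nc2oc(CCCCl)cc2cn1Cc1cn(-c2ccc(Cl)cc2)nn1` has not yet been measured. Going by the values given here, it differs from compound 3 by 4-chlorophenyl in place of benzyl on an aromatic nitrogen, the same change at the same place as the one from compound 2 to compound 1. Resting on an at least 4.5-fold higher number from compound 2 to compound 1 (0.65 log units; beyond the scatter), the step expected for compound 4 is a 4.3-fold higher number from compound 3 to compound 4 (0.63 log units; beyond the scatter). The estimated value for compound 4 in this assay is 120000 nM, likely between 40000 nM and 400000 nM, with a fair chance that only a limit is reported.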

Compound 4, half-maximal inhibitory concentration: 52000 nM
The estimate for compound 4 lay 2.3-fold (0.36 log units) above the measured number, and the stated range covers the measured number.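

In this assay, on the core of compound 3, 4-chlorophenyl in place of benzyl on the aromatic nitrogen gives a 1.9-fold higher number from compound 3 to compound 4 (0.27 log units; within the scatter), so on this core the change stays inside the normal spread of repeat measurements. Set beside the earlier step, this shows neither that the change carries over from one core to the other with the same size nor that its size depends on the core: the same change on two cores in this assay, an at least 4.5-fold higher number (0.65 log units; beyond the scatter) from compound 2 to compound 1 and a 1.9-fold higher number (0.27 log units; within the scatter) from compound 3 to compound 4; the limit leaves it open whether they differ The earlier step is known only as a lower bound, since compound 1 stands at a limit of the assay rather than at a number: the limit of > 100000 nM in this assay, at which 1 of the 4 values shown sits.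

The change from benzyl to 4-chlorophenyl alters two things at once, the carbon link to the ring and the chlorine on it, and the compounds shown do not separate them. A plain phenyl or a 4-chlorobenzyl on the same nitrogen, on either core, would be needed to tell those two parts apart.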